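A few compounds are considered here, and "the series" means these few. Any claim that something is new, unique, unknown or untested is made for them only; others in the source may bear on it.

Values measured in a functional assay on MCF7 cells (Homo sapiens) for cytotoxicity, read by MTT assay, with a stated time of 72 h (on this read-out lower numbers stand for stronger inhibition and higher numbers for weaker inhibition), so far:
- compound 1 `COc1cccc(/C=C2\CCC/C(=C\c3ccccc3Cl)C2=O)c1OC` gives 11300 nM
- compound 2 `COc1cccc(/C=C2\CCC/C(=C\c3cc(Cl)cc(Cl)c3)C2=O)c1OC` gives 4300 nM
- compound 3 `COc1ccc(/C=C2\CCC/C(=C\c3ccc(Cl)cc3)C2=O)cc1OC` gives 6300 nM

Compound 3 lies within the usual scatter of both other compounds, so its number is not clearly separated from either. Compound 4 `COc1ccc(/C=C2\CCC/C(=C\c3ccc(Br)cc3)C2=O)cc1OC` differs from it in one place bromo in place of chloro on an aromatic carbon with bromo in place of chloro on an aromatic carbon, para to a large group. Within the data shown here, the only measured step that offers a guide is a 2.6-fold lower number from compound 1 to compound 2 (0.42 log units; beyond the scatter) and this modest step alters the chlorophenyl group rather than exchanging one halogen for another. Among the measured compounds shown here, no measured step shows chloro giving way to bromo, so no shift beyond the scatter is expected. The estimated change is a 1.1-fold lower number from compound 3 to compound 4 (0.06 log units; within the scatter) in this assay for this pair. The expected value for compound 4 is 5500 nM with an estimated range of 2500 nM to 12000 nM around it.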

Compound 4, half-maximal inhibitory concentration: 6900 nM
Estimate against measurement, compound 4: 1.3-fold (0.10 log units) below, within the range that was stated.
By their numbers in this assay, from the lowest: compounds 2, 3, 4 and 1 (each within the scatter of the next, the first and the last beyond it).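

At this place on the aromatic ring, going from 4-chlorophenyl to 4-bromophenyl gives a 1.1-fold higher number from compound 3 to compound 4 (0.04 log units; within the scatter) in this assay and so does not separate the two halogens. Unlike the earlier step, which moved and added chlorine on the ring, this one exchanges one halogen for another, and the number stays within the scatter. No supporting measurement is available to explain this result. Still open, as far as these compounds go, is whether a group other than a halogen, such as an amine or a carboxylic acid, would shift the number beyond the scatter at this place.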